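This account rests on a few compounds, and the source may have more. Where it says the series, first, only, none or still open, it means among the compounds named here.

Measured compounds:
Compound 1, `COc1ccc(Cl)cc1S(=O)(=O)Nc1cncc(C(=O)Nc2ccccc2)c1`, in an assay on isolated protein for inhibition of alkaline phosphatase, tissue-nonspecific isozyme (Homo sapiens) (a lower number here means a stronger inhibitor, a higher number a weaker inhibitor), compound 1 gives "not determined" (no result reported).
Compound 2, `COc1ccc(Br)cc1S(=O)(=O)Nc1cncc(C(N)=O)c1`, in this assay compound 2 gives 121 nM.
Compound 3, `COc1ccc(C(F)(F)F)cc1S(=O)(=O)Nc1cccnc1`, in this assay compound 3 gives 3010 nM.

Compound 1 therefore stands nowhere on the numbers shown: it has no single value in this assay, and the only readings come from compound 2 and compound 3, which differ from it in more than one place and whose values lie well apart from each other.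

The new compound, compound 4, is `COC(=O)c1cncc(NS(=O)(=O)c2cc(Cl)ccc2OC)c1`. It keeps the shared core of compound 1 and changes only one point: methoxy in place of anilino on a carbonyl carbon. Going by the values given here, no measured pair isolates this change, so the size and direction of the step in this assay cannot be read from the data; without a value for compound 1 there is also no anchor for a direction, and no view is taken on whether the step falls within or beyond the scatter.

What can be said rests on compound 2 with 121 nM and compound 3 with 3010 nM, which bracket the range so far seen. Compound 4 is expected to land in this assay at about 400 nM, estimated between 80 nM and 2500 nM.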

Compound 4, half-maximal inhibitory concentration: > 20000 nM
Compound 4: no number, only a limit; the forecaster's own chance of this, stated with the estimate: 10%; middle value at least 50-fold (1.69 log units) away from the limit.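

Going by these compounds alone, compound 1 has no number in this assay, and compound 4 gives only a limit of the assay, > 20000 nM, so no step between the two can be read. The compounds shown leave open how large the change from phenylcarbamoyl to methoxycarbonyl is in this assay, and in which direction it runs.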